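A few compounds are considered here, and "the series" means these few. Any claim that something is new, unique, unknown or untested is made for them only; others in the source may bear on it.

Going by the values given here, in a functional assay on MDA-MB-231 cells (Homo sapiens), read by microscopy and transwell migration, with a stated time of 24 h (on this read-out higher numbers stand for weaker inhibition and lower numbers for stronger inhibition), compound 2 `CCCCCCn1c(-c2ccc(C)cc2C)cs/c1=N\C(=O)c1ccccc1` gives 45 nM, the lower of the two numbers so far. Its closest comparison, compound 1 `CCCCn1c(-c2ccc(C)cc2C)cs/c1=N\C(=O)c1ccccc1`, gives 196 nM. These two differ only in the length of one chain, and the longer chain of compound 2 goes with the stronger inhibition: a 4.4-fold lower number from compound 1 to compound 2 (0.64 log units; beyond the scatter), from ethyl in place of hydrogen on that chain. Compound 3 `C#CCn1c(-c2ccc(C)cc2C)cs/c1=N\C(=O)c1ccccc1` cuts the chain back, with ethynyl in place of pentyl on a saturated chain carbon bound to an aromatic nitrogen, or hexyl to propargyl. Among the compounds with values here, this single step is the only guide, and no compound measured so far carries a triple bond, so the forecast is loose. It points toward weaker inhibition, and the expected change is a 7.8-fold higher number from compound 2 to compound 3 (0.89 log units; beyond the scatter). For compound 3 the estimated value is 350 nM, with an expected range of 120 nM to 1000 nM.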

Compound 3, half-maximal inhibitory concentration: 3890 nM
The estimate for compound 3 lay 11-fold (1.05 log units) below the measured number; the whole stated range lies below it.
By their numbers in this assay, from the lowest: compound 2; then compound 1; then compound 3.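

Replacing the saturated chain with propargyl costs a great deal of inhibition in this assay: the hexyl to propargyl change gives an 86-fold higher number from compound 2 to compound 3 (1.94 log units; beyond the scatter), and even measured against the shorter saturated chain the change gives a 20-fold higher number from compound 1 to compound 3 (1.30 log units; beyond the scatter). So this position is far from indifferent to what it carries, and across these three compounds the number falls as the chain grows, with none going against that order. No measurement here explains the loss.

Propargyl is both shorter and carries a triple bond, so these compounds cannot separate the two changes; a plain propyl group in the same place would do that. As far as these compounds go, whether the trend continues past hexyl, to an octyl chain, and how an amine at the chain end would fare also remain open.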